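This account rests on a few compounds, and the source may have more. Where it says the series, first, only, none or still open, it means among the compounds named here.

For the measured compounds named here, compound 1 `Nc1cc(N)c2nc(-c3ccccc3)c(Sc3ccc(F)cc3)nc2c1` stands highest of the two numbers so far in a functional assay on LOX IMVI cells (Homo sapiens) for inhibition, read by sulforhodamine B assay, with a stated time of 48 h (a higher number here means a weaker inhibitor of growth, a lower number a stronger inhibitor of growth), where compound 1 gives 40700 nM. Compound 2 `COc1cc(CNc2nc3cc(N)cc(N)c3nc2-c2ccccc2)cc(OC)c1OC` sits well below it in this assay, since compound 2 gives 10500 nM, a gap beyond the usual scatter. Compound 3 `Nc1cc(N)c2nc(-c3ccccc3)c(NCc3ccc(F)cc3)nc2c1` has not yet been tested. It differs from compound 1 in one place: (4-fluorobenzyl)amino in place of (4-fluorophenyl)sulfanyl on an aromatic carbon. Going by the values given here, no measured step isolates this change, so any expectation rests on the two values above. The step of a 2.0-fold lower number from compound 1 to compound 3 (0.31 log units; beyond the scatter) is expected to run toward a lower number, of moderate size. Compound 3 is therefore estimated at 20000 nM, within a range from 7000 nM to 55000 nM.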

Compound 3, concentration for total growth inhibition: 3160 nM
Beside the measured number, compound 3's estimate is 6.3-fold (0.80 log units) above it, and the stated range ends above it.
By their numbers in this assay, from the lowest: compound 3; then compound 2; then compound 1.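

Putting (4-fluorobenzyl)amino in place of (4-fluorophenyl)sulfanyl on this aromatic carbon, next to the ring nitrogen, gives a 13-fold lower number from compound 1 to compound 3 (1.11 log units; beyond the scatter) in this assay, so growth inhibition here depends strongly on the group at this position. The change alters the atom attached to the ring and the link to the fluorinated ring, and it brings in a hydrogen-bond donor, and this single step cannot separate these differences. Nothing measured here accounts for the gain. As far as these compounds go, whether (4-fluorophenyl)amino or (4-fluorobenzyl)sulfanyl would match compound 3 remains open. So does the outcome with an N-methyl group on the linking amine.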